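A few compounds are considered here, and "the series" means these few. Any claim that something is new, unique, unknown or untested is made for them only; others in the source may bear on it.

Compound 1, `CS(=O)(=O)N1CCN(CC(O)CN2CCC(CNC(=O)c3cccc4[nH]c(C5CC5)nc34)CC2)CC1` — in an assay on isolated protein for binding affinity to 5-hydroxytryptamine receptor 3A (Homo sapiens) (a lower number here means a stronger inhibitor, a higher number a weaker inhibitor), compound 1 gives 50100 nM.
Compound 2, `CC(C)(C)c1nc2c(C(=O)NCC3CCN(CC(O)CN4CCN(S(C)(=O)=O)CC4)CC3)cccc2[nH]1` — in this assay compound 2 gives 39800 nM.
Compound 3, `CC(=O)N1CCN(CCN2CCC(CNC(=O)c3cccc4[nH]c(C(C)C)nc34)CC2)CC1` — in this assay compound 3 gives 39800 nM.

Compound 3 stands level with compound 2 at the digits shown, and its gap to compound 1 lies within the scatter, so the three numbers sit together. Among the measured compounds shown here, the one measured step, a 1.3-fold lower number from compound 1 to compound 2 (0.10 log units; within the scatter), alters the group on an aromatic carbon of the shared core and leaves the distal part untouched. Compound 4, `CC(=O)N1CCC(CN2CCC(CNC(=O)c3cccc4[nH]c(C(C)C)nc34)CC2)CC1`, differs from compound 3 by 1-acetylpiperidin-4-yl in place of (4-acetylpiperazin-1-yl)methyl on a saturated chain carbon bound to an amine nitrogen in a ring. For the measured compounds named here, no measured step covers this change, so compound 3 alone sets the starting level. The step expected is a 1.0-fold higher number from compound 3 to compound 4 (0.00 log units; within the scatter), with no move beyond the scatter anticipated. Compound 4 is therefore estimated at 40000 nM, with a range from 15000 nM to 110000 nM.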

Compound 4, inhibition constant: 100000 nM
Compound 4: the middle estimate sits 2.5-fold (0.40 log units) below what was measured, and the stated range covers the measured number.
By their numbers in this assay, from the lowest: compounds 2, 3, 1 and 4 (each within the scatter of the next, the first and the last beyond it).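

On a saturated chain carbon bound to an amine nitrogen in a ring, 1-acetylpiperidin-4-yl in place of (4-acetylpiperazin-1-yl)methyl gives a 2.5-fold higher number from compound 3 to compound 4 (0.40 log units; beyond the scatter) in this assay. This is the first step shown to pass beyond the scatter, and it shows that this place can move the number, towards a weaker inhibitor. Nothing available explains the step. The compounds shown leave open how a carboxylic acid or a longer chain at this place would read. They also leave open whether the same exchange gives a similar step with tert-butyl or cyclopropyl on the shared core.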